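Moving the bromine along the ring at the chain end

A few compounds are considered here, and "the series" means these few. Any claim that something is new, unique, unknown or untested is made for them only; others in the source may bear on it.

Compound 2 `O=C(/C=C\c1cccc(Br)c1)N1N=C(c2ccncc2)OC1c1c[nH]c2ccccc12` and compound 1 `O=C(/C=C\c1ccc(O)cc1)N1N=C(c2ccncc2)OC1c1c[nH]c2ccccc12` share one core and differ only in the group carried on the double-bonded chain. In an ADME assay on A549 cells (Homo sapiens) for cytotoxicity, read by MTT assay, with a stated time of 48 h (on this read-out higher numbers stand for weaker inhibition of growth and lower numbers for stronger inhibition of growth), compound 1 gives > 30 ug/mL, which is a limit of the assay and not a number. In this assay compound 2 gives > 30 ug/mL, likewise a limit and not a number. The step that the two limits leave unreadable from compound 1 to compound 2 therefore cannot be sized. Both results rest on (the limit of > 30 ug/mL in this assay, at which 2 of the 2 values shown sit), so compound 2 stands at the limit, with no readable distance to compound 1.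

Compound 3 `O=C(/C=C\c1ccc(Br)cc1)N1N=C(c2ccncc2)OC1c1c[nH]c2ccccc12` has not been measured. It differs from compound 2 by 4-bromophenyl in place of 3-bromophenyl on a double-bonded chain carbon bound to a double-bonded chain carbon. Among the measured compounds shown here, the single measured step, a step that the two limits leave unreadable from compound 1 to compound 2, concerns a change at the same place and was itself unreadable, so it offers no direction and no size. Compound 3 is therefore expected to show no step beyond the scatter, a step that the limit leaves unreadable from compound 2 to compound 3, in this assay. The estimate for compound 3 in this assay is 40 ug/mL, with a range from 15 ug/mL to 120 ug/mL, and the result is expected most often to come back as a limit once more.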

Compound 3, concentration for 50% growth inhibition: > 30 ug/mL
Compound 3: a limit, no number (the forecaster's own chance of this, stated with the estimate: 75%); the middle value is on the limit's open side.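

Like compound 1 and compound 2, compound 3 returns a limit and not a number, so no step among these three compounds can be read: the limit of > 30 ug/mL in this assay, at which 3 of the 3 values shown sit.

Left open is how strongly any of the three inhibits growth in this assay, and so whether 4-hydroxyphenyl, 3-bromophenyl and 4-bromophenyl differ there at all.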